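The source may hold more compounds than are shown below. What is called first, only, known or untested is meant among the compounds shown, and "the series" means these compounds.

Values in an assay on T-REx-293 cells for inhibition of potassium channel subfamily T member 1 (Homo sapiens), read by patch clamp (a higher number here means a weaker inhibitor, a lower number a stronger inhibitor), for the measured members of the series:

compound 1 `Cc1cncc(-c2noc([C@H](C)NC(=O)c3cc(C(F)(F)F)nn3C)n2)c1`: 1370 nM
compound 2 `COCc1cc(-c2noc([C@H](C)NC(=O)c3cc(C(F)(F)F)nn3C)n2)ccn1`: 322 nM
compound 3 `COC(C)(C)c1cc(-c2noc([C@H](C)NC(=O)c3cc(C(F)(F)F)nn3C)n2)ccn1`: 6280 nM

Compound 3 stands highest of the three numbers, beyond the scatter from both others; compound 2 is the lowest, and compound 1 sits in between.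

The next step goes from compound 3 to compound 4 `CO[C@H](C)c1cc(-c2noc([C@H](C)NC(=O)c3cc(C(F)(F)F)nn3C)n2)ccn1`: 1-methoxyethyl in place of 1-methoxy-1-methylethyl on an aromatic carbon. The change keeps the ring and the ether and removes one carbon.

Two measured steps are on record. The step of a 4.3-fold lower number from compound 1 to compound 2 (0.63 log units; beyond the scatter) changed the ring and the substituent together and bears little on this step. The step of a 20-fold higher number from compound 2 to compound 3 (1.29 log units; beyond the scatter) is the relevant one: adding two carbons at this position gave a large rise. Compound 4 takes one of those two carbons away again, so a partial reversal of that rise is expected, with the stereocentre as an open point. The expected step is a 4.5-fold lower number from compound 3 to compound 4 (0.65 log units; beyond the scatter) in this assay. For compound 4 the estimate is 1400 nM, with a range from 400 nM to 5000 nM.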

Compound 4, half-maximal inhibitory concentration: 778 nM
The estimate for compound 4 lay 1.8-fold (0.26 log units) above the measured number; the measured number falls inside the stated range.
By their numbers in this assay, from the lowest: compound 2; then compounds 4 and 1 (each within the scatter of the next); then compound 3.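

In this assay the 1-methoxyethyl group gives an 8.1-fold lower number from compound 3 to compound 4 (0.91 log units; beyond the scatter) against 1-methoxy-1-methylethyl and still gives a 2.4-fold higher number from compound 2 to compound 4 (0.38 log units; beyond the scatter) against methoxymethyl, so at this carbon next to the ring nitrogen the second methyl on the chain carbon accounts for more of the rise than the first, though both steps lie beyond the scatter. The step of a 1.8-fold lower number from compound 1 to compound 4 (0.25 log units; within the scatter) lies within the scatter, so this one added methyl already removes the separation from compound 1 that compound 2 held. Nothing on record explains the size of either methyl's contribution.

Going by these compounds, only one configuration of 1-methoxyethyl appears, so the effect of the opposite stereocentre remains unknown. Also open, on these data alone, is whether an ethoxymethyl, a hydroxymethyl or an aminomethyl group at this carbon would match compound 2.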